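Carbamate series: phenyl to benzyl on the nitrogen

A few compounds are considered here, and "the series" means these few. Any claim that something is new, unique, unknown or untested is made for them only; others in the source may bear on it.

Measured in a functional assay on MDA-MB-231 cells (Homo sapiens) for antiproliferative activity, read by MTT assay, with a stated time of 96 h; on this read-out higher numbers stand for weaker inhibition and lower numbers for stronger inhibition:
- compound 1 `CC(C)=CCC/C(C)=C/CC/C(C)=C/CC[C@]1(C)CCc2c(C)c(OC(=O)Nc3ccccc3)c(C)c(C)c2O1`: > 10000 nM, a limit
- compound 2 `CC(C)=CCC/C(C)=C/CC/C(C)=C/CC[C@]1(C)CCc2cc(OC(=O)Nc3ccccc3)c(C)c(C)c2O1`: > 10000 nM, a limit

Compound 2 has no numerical value in this assay: its result, > 10000 nM, is only a limit. Among the compounds with values here, the other result, for compound 1, is a limit as well, so the series so far rests on (the limit of > 10000 nM in this assay, at which 2 of the 2 values shown sit).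

The next compound is compound 3 `CC(C)=CCC/C(C)=C/CC/C(C)=C/CC[C@]1(C)CCc2cc(OC(=O)NCc3ccccc3)c(C)c(C)c2O1`, with benzyl in place of phenyl on an amide-type nitrogen.

Within the data shown here, the only measured step is a step that the two limits leave unreadable from compound 1 to compound 2. That step is hydrogen in place of methyl on an aromatic carbon, so it concerns a different place from the present change and gives no size to carry over. Among the measured compounds shown here, with no measured step on the nitrogen substituent, no direction can be argued for this assay, and no shift beyond the scatter is expected. The expected step is a number no higher from compound 2 to compound 3 (the limit leaves the size open). A report at the same limit is considered the likeliest outcome. For compound 3 the estimated value is 10000 nM, with an expected range from 3000 nM to 30000 nM.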

Compound 3, half-maximal inhibitory concentration: > 10000 nM
Compound 3 gave a limit, no number; the forecaster's own chance of this, stated with the estimate: 65%; the middle value lies on the limit itself.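

In this assay compound 3 gives > 10000 nM, which is a limit. Compound 2 also stands at a limit, so no step can be read between compound 2 and compound 3, and benzyl in place of phenyl on the nitrogen has no readable size. The compounds shown leave open whether any change in this series gives a numerical value in this assay: the limit of > 10000 nM in this assay, at which 3 of the 3 values shown sit.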